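This account rests on a few compounds, and the source may have more. Where it says the series, first, only, none or still open, it means among the compounds named here.

Three compounds of the series have been run in a functional assay on HT-29 cells (Homo sapiens) for cytotoxicity, read by MTT assay, with a stated time of 72 h; a higher number here means that more compound is tolerated, a lower number that less compound is tolerated. Within the data shown here, compound 1 `CSc1ccc(CNc2nc(SC)nc3ncccc23)cc1` gives 8750 nM and is the only member with a number in this assay. Compound 2 `CCCCC[Se]c1nc(N)c2ccccc2n1` returns only a limit, > 100000 nM. Compound 3 `CCCCCSc1nc(NCc2ccc([Se]C)cc2)c2ccccc2n1` likewise returns only a limit, > 100000 nM. Two of the three results therefore sit at the limit of > 100000 nM in this assay, at which 2 of the 3 values shown sit. Among the measured compounds shown here, compound 1 thus stands alone as the one compound with a measured concentration, and no step between measured compounds can be drawn from what is in hand.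

Compound 4 `CSc1nc(NCc2ccccc2)c2cccnc2n1` is not yet measured. It differs from compound 1 by hydrogen in place of methylsulfanyl on an aromatic carbon, the methylsulfanyl group leaving from an aromatic carbon of the six-membered aromatic ring of carbon only, para to a large group. Without a measured step the size of the change can only be guessed; a step in this assay of modest size, toward a higher number or none beyond the scatter, is expected. For compound 4 the expected value is 13000 nM, within 4000 nM to 45000 nM, corresponding to an expected step of a 1.5-fold higher number from compound 1 to compound 4 (0.17 log units; within the scatter).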

Compound 4, concentration lethal to 50% of the cells: > 100000 nM
Compound 4 was reported as a limit; the forecaster's own chance of this, stated with the estimate: 10%; middle value at least 7.6-fold (0.88 log units) from the limit.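

In this assay, among these compounds, the methylsulfanyl group on the six-membered aromatic ring of carbon only gives the first readable change: hydrogen in its place gives an at least 11-fold higher number from compound 1 to compound 4 (1.05 log units; beyond the scatter). Going by these compounds, compound 4 gives > 100000 nM, which is a limit and not a number, so the true size of the step remains unknown. Compound 1, which carries the group, remains the only compound with a measured concentration, while the others share the limit: the limit of > 100000 nM in this assay, at which 3 of the 4 values shown sit.

On these data alone, whether a methoxy group, a chlorine atom or an amine at this position would also give a measured concentration remains open. Among the compounds shown here, compound 2 and compound 3 differ from compound 1 in more than one place, and no steps to them can be read.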